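Solubility notes: benzyl-type substituent returns with two methyls

The source may hold more compounds than are shown below. What is called first, only, known or untested is meant among the compounds shown, and "the series" means these compounds.

The series shares one core, varied at a single aromatic carbon of the fused ring pair. Compound 1 `COc1cccc(CNCCCNc2ccnc3cc(Cc4ccccc4)ccc23)c1O` carries a benzyl there; compound 2 `COc1cccc(CNCCCNc2ccnc3cc(-c4ccc(F)cc4)ccc23)c1O` carries a 4-fluorophenyl. Among the compounds with values here, in a physicochemical assay for solubility, with a stated time of 18 h, at pH 7.4 (on this read-out lower numbers stand for lower solubility and higher numbers for higher solubility), compound 1 gives 4200 nM, while compound 2 gives 32000 nM, which is the higher of the two numbers so far; the single recorded step, a 7.6-fold higher number from compound 1 to compound 2 (0.88 log units; beyond the scatter), is the only one that bears on the present change.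

Compound 3 `COc1cccc(CNCCCNc2ccnc3cc(Cc4cc(C)cc(C)c4)ccc23)c1O` has not yet been measured. Relative to compound 2, (3,5-dimethylbenzyl in place of 4-fluorophenyl on an aromatic carbon). This change returns to the benzyl-type substituent of compound 1 and adds two methyl groups to that ring. The step from compound 1 to compound 2 was modest but beyond the scatter, so its reversal is expected to pull the number back down from compound 2 toward the value of compound 1, 4200 nM. Within the data shown here, no measured step covers the two methyls, and they are given no separate weight here. The expected step from compound 2 to compound 3 is therefore a 13-fold lower number from compound 2 to compound 3 (1.11 log units; beyond the scatter). For compound 3 the estimate in this assay is 2500 nM, within a range of 700 nM to 9000 nM.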

Compound 3, solubility: 4200 nM
The estimate for compound 3 lay 1.7-fold (0.23 log units) below the measured number; measured number inside the range.
By their numbers in this assay, from the lowest: compounds 1 and 3 (each within the scatter of the next); then compound 2.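

In this assay, 3,5-dimethylphenyl in place of phenyl on the saturated chain carbon gives no change at the digits printed from compound 1 to compound 3 (within the scatter), so the two benzyl-type compounds at this aromatic carbon cannot be told apart on this read-out. Exchanging 4-fluorophenyl for 3,5-dimethylbenzyl gives a 7.6-fold lower number from compound 2 to compound 3 (0.88 log units; beyond the scatter), matching in size the earlier step in the other direction, a 7.6-fold higher number from compound 1 to compound 2 (0.88 log units; beyond the scatter); among these three compounds, compound 2 stands apart from both benzyl-type compounds, with each gap beyond the scatter. No measurement is available that would account for this grouping.

The compounds shown do not separate the presence of the saturated chain carbon from the fluorine of compound 2, and a plain phenyl or a 3,5-dimethylphenyl bound directly to the same aromatic carbon would be needed to pull those two differences apart. Within the data shown here, also open is how a morpholine, a primary amine or a carboxylic acid on the ring of the benzyl group would read in this assay, as every substituent here carries only carbon and hydrogen, apart from the single fluorine of compound 2.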